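From a Furanylmethyl Ester to a Propyl Amide

A few compounds are considered here, and "the series" means these few. Any claim that something is new, unique, unknown or untested is made for them only; others in the source may bear on it.

Compound 1 `C/C=C1/[C@H](O[C@@H]2O[C@H](CO)[C@@H](O)[C@H](O)[C@H]2O)OC=C(C(=O)OC)[C@H]1CC(=O)OCc1ccco1`: > 15000 nM in a functional assay on SK-BR-3 cells (Homo sapiens) for antiproliferative activity, read by MTT assay, with a stated time of 72 h; a higher number here means a weaker inhibitor, a lower number a stronger inhibitor
Compound 2 `C/C=C1/[C@H](O[C@@H]2O[C@H](CO)[C@@H](O)[C@H](O)[C@H]2O)OC=C(C(=O)O)[C@H]1CC(=O)OC`: > 20000 nM in this assay

In this assay compound 1 gives only a limit, (the limit of > 15000 nM in this assay, at which 1 of the 2 values shown sits), so no actual number is known for it. Compound 2 likewise gives only a limit, (the limit of > 20000 nM in this assay, at which 1 of the 2 values shown sits). Among the measured compounds shown here, with two limits and no measured step between them, the two values show only that both compounds lie beyond what the measurement resolves.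

Compound 3 `C/C=C1/[C@H](O[C@@H]2O[C@H](CO)[C@@H](O)[C@H](O)[C@H]2O)OC=C(C(=O)OC)[C@H]1CC(=O)NCCC` keeps the core of compound 1 and changes one group: propylamino in place of (furan-2-yl)methoxy on a carbonyl carbon. Nothing measured here ties that change to a shift in activity. Since compound 1 stands at a limit (the limit of > 15000 nM in this assay, at which 1 of the 2 values shown sits), compound 3 is expected to stay in the same weak region, with a step that the limit leaves unreadable from compound 1 to compound 3 expected to be none beyond the scatter. Compound 3 is estimated at 20000 nM, within a range from 8000 nM to 60000 nM, most likely reported again as a limit.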

Compound 3, half-maximal inhibitory concentration: > 20000 nM
Compound 3: a limit, no number; the forecaster's own chance of this, stated with the estimate: 80%; the middle value sits exactly at the limit.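

Compound 3 gives > 20000 nM in this assay, which is a limit and not a number. Among the compounds shown here, compound 1 also gives only a limit, so no step from compound 1 to compound 3 can be read. The compounds shown leave open whether propylamino in place of (furan-2-yl)methoxy changes activity at all.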